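Methylsulfanyl in Place of Aminoamino: Compound 3 to Compound 4

A few compounds are considered here, and "the series" means these few. Any claim that something is new, unique, unknown or untested is made for them only; others in the source may bear on it.

Measured so far in a functional assay, with a stated time of 20 min; a lower number here means a stronger inhibitor, a higher number a weaker inhibitor:
Compound 1, `Cn1c(NN)nc(-c2cccc(O)c2O)c(C#N)c1=O`, gives 34 ug/mL.
Compound 2, `CSc1nc(-c2cccs2)c(C#N)c(=O)n1C`, gives 71 ug/mL.
Compound 3, `Cn1c(NN)nc(-c2ccco2)c(C#N)c1=O`, gives 64 ug/mL.

Compound 3 stands second highest of these three numbers. Compound 2 lies closest to it and compound 1 furthest, yet both gaps fall within the usual scatter, so the three compounds cannot be ranked against each other.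

Compound 4, `CSc1nc(-c2ccco2)c(C#N)c(=O)n1C`, differs from compound 3 in one place: methylsulfanyl in place of aminoamino on an aromatic carbon. For the measured compounds named here, no measured pair isolates this exact change. Compound 2 also carries methylsulfanyl, but on a different aryl group, so it only shows that such a compound landed close to compound 3 in this assay. The step from compound 3 to compound 4 is therefore expected to stay within the scatter, as a 1.1-fold higher number from compound 3 to compound 4 (0.04 log units; within the scatter). Compound 4 is estimated at 70 ug/mL, with a range of 35 ug/mL to 140 ug/mL.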

Compound 4, half-maximal inhibitory concentration: 68 ug/mL
Estimate against measurement, compound 4: 1.0-fold (0.01 log units) above, and the stated range covers the measured number.
By their numbers in this assay, from the lowest: compounds 1, 3, 4 and 2 (each within the scatter of the next, the first and the last beyond it).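

In this assay, for the compounds shown here, a 1.1-fold higher number from compound 3 to compound 4 (0.03 log units; within the scatter) gives the first direct reading of this change on the aromatic carbon between two ring nitrogen atoms: methylsulfanyl in place of aminoamino has no effect that can be told from the scatter. With methylsulfanyl in place, furan-2-yl in place of thiophen-2-yl, a 1.0-fold lower number from compound 2 to compound 4 (0.02 log units; within the scatter), likewise stays within the scatter. No evidence here explains either result. As far as these compounds go, whether a larger group on this carbon, such as dimethylamino or a longer sulfur-linked chain like butylsulfanyl, would move the number remains open.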